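Benzyl Substituent Variation in an Antiproliferative Nucleoside Series

This account rests on a few compounds, and the source may have more. Where it says the series, first, only, none or still open, it means among the compounds named here.

Measured so far:
compound 1 `OC[C@H]1O[C@@H](n2cnc3c(NCc4ccccc4Cl)ncnc32)[C@H](O)[C@@H]1O`: 64000 nM
compound 2 `Cc1cccc(CNc2ncnc3c2ncn3[C@@H]2O[C@H](CO)[C@@H](O)[C@H]2O)c1`: > 166000 nM, a limit of the assay
compound 3 `OC[C@H]1O[C@@H](n2cnc3c(NCc4ccc(F)c(F)c4F)ncnc32)[C@H](O)[C@@H]1O`: > 166000 nM, a limit of the assay

In a functional assay on K562 cells (Homo sapiens) for antiproliferative activity, with a stated time of 72 h (on this read-out lower numbers stand for stronger inhibition and higher numbers for weaker inhibition), compound 1 gives 64000 nM. For compound 2 only the limit > 166000 nM is known. Compound 2 therefore stands at the limit of > 166000 nM in this assay, at which 2 of the 3 values shown sit, where compound 3 also sits. The step of an at least 2.5-fold higher number from compound 1 to compound 2 (0.41 log units; beyond the scatter) and the step of an at least 2.5-fold higher number from compound 1 to compound 3 (0.41 log units; beyond the scatter) both run from a number to a limit, and the step that the two limits leave unreadable from compound 2 to compound 3 is unreadable.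

Compound 4 `OC[C@H]1O[C@@H](n2cnc3c(NCc4ccccc4OC(F)F)ncnc32)[C@H](O)[C@@H]1O` differs from compound 2 by 2-(difluoromethoxy)phenyl in place of 3-methylphenyl on a saturated chain carbon bound to a nitrogen on an aromatic ring. Within the data shown here, no measured step covers this change. Among the measured compounds shown here, the only bearing step is an at least 2.5-fold higher number from compound 1 to compound 2 (0.41 log units; beyond the scatter), which shows 2-chlorophenyl giving a readable number where 3-methylphenyl gives none; compound 4 again carries a substituent at the 2-position of the phenyl. A move back below the limit is expected, roughly an at least 2.0-fold lower number from compound 2 to compound 4 (0.31 log units; beyond the scatter). Compound 4 is thus estimated at 80000 nM, within 30000 nM to 200000 nM, with a real chance that only a limit is reported.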

Compound 4, half-maximal inhibitory concentration: > 166000 nM
Compound 4: only a limit was reported (the forecaster's own chance of this, stated with the estimate: 35%); at least 2.0-fold (0.31 log units) between middle value and limit.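

In this assay, 2-(difluoromethoxy)phenyl gives no readable number where 2-chlorophenyl does, so difluoromethoxy in place of chloro on an aromatic carbon gives an at least 2.5-fold higher number from compound 1 to compound 4 (0.41 log units; beyond the scatter). Compound 1 remains the only compound shown with a number, and the steps among compound 2, compound 3 and compound 4 cannot be read. The series now gathers at one limit: the limit of > 166000 nM in this assay, at which 3 of the 4 values shown sit.

Open, going by these compounds, is whether bromo, methoxy or an amine in place of chloro on an aromatic carbon would also give a readable number, or whether chloro stands alone here.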